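The source may hold more compounds than are shown below. What is called first, only, known or untested is meant among the compounds shown, and "the series" means these compounds.

Compound 1 `Nc1scc(CN2CCN(c3cccnc3)CC2)c1C(=O)c1ccc(Cl)cc1` and compound 2 `Nc1scc(CN2CCN(c3cccc(F)c3)CC2)c1C(=O)c1ccc(Cl)cc1` share one core and differ only in the ring on the amine nitrogen. In a functional assay on CHO cells with adenosine receptor A1 (Homo sapiens) as the target, read by cAMP accumulation and immunoassay, with a stated time of 6 min, tested at 0.01 uM (on this read-out higher numbers stand for a weaker effect at the one concentration tested and lower numbers for a stronger effect), compound 1 gives 3.2%, while compound 2 gives -18%. Among the compounds with values here, the single measured step, a number 21.2 percentage points lower from compound 1 to compound 2 (beyond the scatter), replaces the whole ring rather than one atom on it. Within the data shown here, compound 2 therefore stands lowest of the two numbers recorded, with compound 1 the only neighbour.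

Compound 3 `Nc1scc(CN2CCN(c3ccc(F)c(F)c3)CC2)c1C(=O)c1ccc(Cl)cc1` differs from compound 2 by fluoro in place of hydrogen on an aromatic carbon. Among the measured compounds shown here, no measured step swaps a hydrogen for a fluoro on a ring carbon, so the one step on record does not bear on this change and gives no direction. The expectation for compound 3 is accordingly a step of a number 3 percentage points higher from compound 2 to compound 3 (within the scatter), not beyond the scatter. Compound 3 is thus estimated at -15%, with a range from -40% to 10%.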

Compound 3, a percentage reported as activity, at one concentration (the size of the read-out at that concentration, not a potency): -3.2%
Compound 3: the middle estimate sits 11.8 percentage points below what was measured, within the range that was stated.
By their numbers in this assay, from the lowest: compound 2; then compounds 3 and 1 (each within the scatter of the next).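

Fluoro in place of hydrogen on this aromatic carbon, ortho to a fluoro group and para to a large group, is not a silent change in this assay: the step is a number 14.8 percentage points higher from compound 2 to compound 3 (beyond the scatter), towards the weaker effect, and it takes back much of the gain seen with the 3-fluorophenyl ring. The other new step is a number 6.4 percentage points lower from compound 1 to compound 3 (within the scatter), so the 3,4-difluorophenyl ring, unlike the 3-fluorophenyl ring, does not stand apart from pyridin-3-yl by more than the scatter. Nothing on hand accounts for either step.

The compounds shown leave open whether a methyl or methoxy group, an amine or a carboxylic acid on this same carbon would move the number as fluoro does. They also leave open whether the same change would give a step of like size on the pyridin-3-yl ring of compound 1.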